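Fluoro on the pyridinyl ring of an arylpiperazine series

A few compounds are considered here, and "the series" means these few. Any claim that something is new, unique, unknown or untested is made for them only; others in the source may bear on it.

Compound 1 `CNc1ccccc1N1CCN(CCCCn2ncc(=O)n(C)c2=O)CC1`: 450 nM
Compound 2 `Cn1c(=O)cnn(CCCCN2CCN(c3ccccn3)CC2)c1=O`: 262 nM

In an assay for displacement of a labelled ligand from Adrenergic receptor alpha-1 (Homo sapiens) (on this read-out higher numbers stand for weaker inhibition and lower numbers for stronger inhibition), compound 1 gives 450 nM and compound 2 gives 262 nM. The two numbers sit within the scatter of each other: a 1.7-fold lower number from compound 1 to compound 2 (0.23 log units; within the scatter). Compound 2 thus stands with compound 1 in the same band, and nothing separates the two beyond the usual spread.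

Compound 3 `Cn1c(=O)cnn(CCCCN2CCN(c3cccc(F)n3)CC2)c1=O` differs from compound 2 in one place: fluoro in place of hydrogen on an aromatic carbon. Among the compounds with values here, the only measured step, from compound 1 to compound 2, exchanged the whole aryl group on the amine nitrogen and stayed within the scatter, so it bears on the present change only loosely; no measured step adds a fluoro to an aromatic carbon. No shift beyond the scatter is therefore expected, a 1.0-fold lower number from compound 2 to compound 3 (0.00 log units; within the scatter). Compound 3 is estimated at 260 nM, with a range from 110 nM to 600 nM.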

Compound 3, inhibition constant: > 10000 nM
Compound 3: no number, only a limit; the forecaster's own chance of this, stated with the estimate: 3%; middle value at least 38-fold (1.58 log units) away from the limit.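

Compound 3 stands at a limit of this assay, not at a number: the limit of > 10000 nM in this assay, at which 1 of the 3 values shown sits.

A single fluoro next to the ring nitrogen of the pyridin-2-yl group is therefore no minor edit here, giving an at least 38-fold higher number from compound 2 to compound 3 (1.58 log units; beyond the scatter). The exchange of the whole aryl group from compound 1 to compound 2 stayed within the scatter, whereas 6-fluoropyridin-2-yl in that same place gives an at least 22-fold higher number from compound 1 to compound 3 (1.34 log units; beyond the scatter), so among these three compounds the added fluoro alone separates compound 3 from the other two.

Going by these compounds, whether this drop belongs to fluoro itself or to any group at this carbon stays open, and a chloro or a methyl there, or a fluoro elsewhere on the ring, would bear on that. On these data alone, how far compound 3 lies beyond the limit also remains unknown, so both steps give only a lower bound.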